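A few compounds are considered here, and "the series" means these few. Any claim that something is new, unique, unknown or untested is made for them only; others in the source may bear on it.

Compound 1 `c1ccc2nc3c(cc2c1)Cn1c-3nc2ccccc21`: 12000 nM
Compound 2 `Cc1cccc2cc3c(nc12)-c1nc2ccccc2n1C3`: > 100000 nM (a limit of the assay)
Compound 3 `Cc1ccc2cc3c(nc2c1)-c1nc2ccccc2n1C3`: > 100000 nM (a limit of the assay)

For the measured compounds named here, in a functional assay on MDA-MB-231 cells (Homo sapiens) for cytotoxicity, read by MTT assay, with a stated time of 72 h (on this read-out higher numbers stand for weaker inhibition and lower numbers for stronger inhibition), compound 1 gives 12000 nM, the only actual number in this small set. Compound 2 is reported only as a limit, > 100000 nM. Compound 3 is likewise reported only as a limit, > 100000 nM.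

Compound 4 `Cc1ccc2nc3c(cc2c1)Cn1c-3nc2ccccc21` keeps the core of compound 1 and carries methyl in place of hydrogen on an aromatic carbon. Two measured steps make the same kind of swap, though on other carbons: an at least 8.3-fold higher number from compound 1 to compound 2 (0.92 log units; beyond the scatter), and an at least 8.3-fold higher number from compound 1 to compound 3 (0.92 log units; beyond the scatter). Both point towards weaker inhibition, and neither has a known full size, since each ends at the limit of > 100000 nM in this assay, at which 2 of the 3 values shown sit. With only these two precedents, a step towards weaker inhibition in this assay is expected for the new position as well, though perhaps a smaller one. The expected step is a 3.3-fold higher number from compound 1 to compound 4 (0.52 log units; beyond the scatter). For compound 4 the estimated value is 40000 nM, with an expected range from 10000 nM to 150000 nM.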

Compound 4, half-maximal inhibitory concentration: > 100000 nM
Compound 4 ended at the assay's limit; the forecaster's own chance of this, stated with the estimate: 35%; at least 2.5-fold (0.39 log units) between middle value and limit.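

With an at least 8.3-fold higher number from compound 1 to compound 4 (0.92 log units; beyond the scatter), methyl on this carbon, meta to a fused ring and para to a fused ring, joins the two other methyl placements: in this assay all three shown move towards weaker inhibition, and none goes against this. From the compounds shown here alone, compound 4 is reported only as a limit, > 100000 nM, so the full size of its step remains unknown, and compounds 2, 3 and 4 cannot be ranked against one another. The set now gathers at a single ceiling: the limit of > 100000 nM in this assay, at which 3 of the 4 values shown sit.

The compounds shown leave open how a fluorine, an amine or a carboxylic acid would read at this place in this assay. They also leave open whether a longer chain would follow methyl, or whether any group on this carbon would keep the value of compound 1.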